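The source may hold more compounds than are shown below. What is called first, only, known or untested is meant among the compounds shown, and "the series" means these compounds.

In a functional assay on A549 cells (Homo sapiens) for antiproliferative activity, read by MTT assay, with a stated time of 48 h (on this read-out higher numbers stand for weaker inhibition and lower numbers for stronger inhibition), compound 1 `COc1cc(-c2cccc3nc(-c4ccccc4)oc23)cc(OC)c1OC` gives 20300 nM, while compound 2 `COc1cc(-c2cccc3nc(-c4cccc(O)c4)oc23)cc(OC)c1OC` gives 2000 nM, the lower of the two numbers. Compound 3 `COc1cc(-c2cccc3nc(-c4ccc5cc[nH]c5c4)oc23)cc(OC)c1OC` departs from compound 2 by 1H-indol-6-yl in place of 3-hydroxyphenyl on an aromatic carbon, with 1H-indol-6-yl in place of 3-hydroxyphenyl on an aromatic carbon. Among the compounds with values here, the one measured step, a 10-fold lower number from compound 1 to compound 2 (1.01 log units; beyond the scatter), is large, but it concerns adding hydroxy and does not measure this exchange. The new group also lacks the hydroxy, so no large step is expected in this assay. The estimated change, a 1.7-fold lower number from compound 2 to compound 3 (0.22 log units; within the scatter), is expected to stay within the scatter. For compound 3 the estimated value is 1200 nM, with an expected range of 200 nM to 8000 nM.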

Compound 3, half-maximal inhibitory concentration: 55 nM
Estimate against measurement, compound 3: 22-fold (1.34 log units) above; the measured number lies below the stated range.
By their numbers in this assay, from the lowest: compound 3; then compound 2; then compound 1.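

In this assay, the aromatic carbon next to the ring nitrogen and the ring oxygen proves far more sensitive to the aryl group than the hydroxy step alone suggested: 1H-indol-6-yl gives a 36-fold lower number from compound 2 to compound 3 (1.56 log units; beyond the scatter) and a 370-fold lower number from compound 1 to compound 3 (2.57 log units; beyond the scatter). The entering group carries no hydroxy, so among these three compounds the lowest number does not require one. No available evidence accounts for this gain. From the compounds shown here alone, whether the hydrogen on the indole nitrogen matters remains open. So does how a phenyl ring bearing an amine or a carboxylic acid would behave at this position.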